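A few compounds are considered here, and "the series" means these few. Any claim that something is new, unique, unknown or untested is made for them only; others in the source may bear on it.

Of the compounds shown here, three built on one shared core have been tested in a functional assay on SV5A8 cells (Homo sapiens) for cytotoxicity (on this read-out lower numbers stand for stronger inhibition and higher numbers for weaker inhibition), and every one of them returns only a limit. Compound 1 `Cc1ccc2c(NCc3ccc(NC(=O)C4CCN(Cc5cc(Cl)ccn5)CC4)cc3)nc(N(C)C)nc2c1` gives > 5400 nM, a limit of the assay. Compound 2 `Cc1ccc2c(NCc3ccc(NC(=O)C4CCN(CC5CCNCC5)CC4)cc3)nc(N(C)C)nc2c1` gives > 8070 nM, likewise a limit. Compound 3 `Cc1ccc2c(NCc3ccc(NC(=O)C4CCN(Cc5ccco5)CC4)cc3)nc(N(C)C)nc2c1` gives > 20000 nM, again a limit rather than a number. Among the values shown, compound 3 therefore sits at the limit of > 20000 nM in this assay, at which 1 of the 3 values shown sits, and nothing in the set orders it against the others. The steps at the same place, a step that the two limits leave unreadable from compound 1 to compound 2, a step that the two limits leave unreadable from compound 1 to compound 3 and a step that the two limits leave unreadable from compound 2 to compound 3, are all unreadable, so none of them shows a size or a direction. Compound 4 `Cc1ccc2c(NCc3ccc(NC(=O)C4CCN(Cc5ccc(F)cc5)CC4)cc3)nc(N(C)C)nc2c1` differs from compound 3 by 4-fluorophenyl in place of furan-2-yl on a saturated chain carbon bound to an amine nitrogen in a ring. The three measured steps bear on this change only in that they swap a group at the same saturated chain carbon bound to an amine nitrogen in a ring; none supports an expected step beyond the scatter. Compound 4 is therefore expected to remain in the same weak region, with the step of an at least 1.3-fold lower number from compound 3 to compound 4 (0.12 log units; that floor lies within the scatter) estimated only loosely. The estimate for compound 4 in this assay is 15000 nM, with a range from 4000 nM to 60000 nM.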

Compound 4, half-maximal inhibitory concentration: > 4820 nM
Compound 4: a limit, no number (the forecaster's own chance of this, stated with the estimate: 75%); the middle value lies beyond the limit too.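

Compound 4 also returns only a limit, so its steps from compound 1, compound 2 and compound 3 cannot be read in size or direction. The compounds shown leave open whether any of these four groups on the saturated chain carbon bound to an amine nitrogen in a ring gives a number rather than a limit in this assay.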